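Chloro-to-hydrogen step on the aryl ring of compound 1

The source may report more compounds than this note shows. Statements on the series, on what has been measured and on what is new or still open speak of the compounds shown alone.

Measured so far:
compound 1 `S=c1s/c(=N\c2ccc(Cl)cc2)n2n1CCCC2`, 339 nM
compound 2 `C#CCOc1cc(/N=c2\sc(=S)n3n2CCCC3)c(F)cc1Cl`, 7.24 nM

Both compounds were run in a functional assay on the whole organism for inhibition, with Scenedesmus acutus as the target; a higher number here means a weaker inhibitor, a lower number a stronger inhibitor. Compound 1 gives the higher of the two numbers recorded; compound 2 gives a number far lower, and the gap between the two values lies well beyond the scatter of repeated runs. For the measured compounds named here, compound 2 carries several additional groups on its aryl ring, so no single structural step links it to compound 1, and nothing more than this comparison of the two values can be read from the pair.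

Compound 3 `S=c1s/c(=N\c2ccccc2)n2n1CCCC2` is the unmeasured member. It differs from compound 1 in one place, (hydrogen in place of chloro on an aromatic carbon), so the chloro that sits para to a large group on the ring is simply lost.

Going by the values given here, no step between two measured compounds in this assay has been characterised, so the size of the change is a judgement. The expectation is a moderate rise in the number for compound 3, that is a somewhat weaker inhibitor, of a size beyond the scatter but not large. Compound 3 is estimated at 1000 nM, with a range of 300 nM to 3500 nM. This estimate corresponds to an expected step of a 2.9-fold higher number from compound 1 to compound 3 (0.47 log units; beyond the scatter).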

Compound 3, half-maximal inhibitory concentration: 14100 nM
For compound 3 the middle estimate is 14-fold (1.15 log units) below the measured one; the whole stated range lies below it.
By their numbers in this assay, from the lowest: compound 2; then compound 1; then compound 3.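

Working notes on the chloro position. In this assay, for the compounds shown here, the exchange of chloro for hydrogen on the aromatic carbon para to a large group gives a 42-fold higher number from compound 1 to compound 3 (1.62 log units; beyond the scatter) and is the first single-place step that can be read, which the pair of compound 1 and compound 2 could not supply. The position is therefore far from indifferent: the loss of one chlorine atom, with no ring, no hydrogen-bond donor or acceptor and no net charge involved, is enough to produce a large step, and the chloro is clearly worth keeping on the core of compound 1 when the only alternative shown is hydrogen. No measurement at hand bears on the origin of this step.

Still open, as far as these compounds go, is whether another group at this place, such as fluoro, bromo, methyl or methoxy, would hold the number of compound 1 at 339 nM or move it in either direction. Also open, from the compounds shown here alone, is whether a step of this size would carry over to the more heavily substituted aryl ring of compound 2.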